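Pyrazoline amides: expectation for a piperazinyl acetyl analogue

This account rests on a few compounds, and the source may have more. Where it says the series, first, only, none or still open, it means among the compounds named here.

Measured compounds:
compound 1 `CC1=NN(C(=O)CCc2ccccc2)C(c2cc(Br)ccc2O)C1` — 21200 nM
compound 2 `CC1=NN(S(=O)(=O)c2ccc(C)cc2)C(c2cc(Br)cc(Br)c2O)C1` — "not active" (no number reported)
compound 3 `O=C(c1ccccc1Cl)N1N=C(c2cc3ccccc3oc2=O)CC1c1ccccc1` — 6640 nM

In a functional assay on MGC-803 cells (Homo sapiens) for cytotoxicity, read by MTT assay, with a stated time of 48 h (on this read-out lower numbers stand for stronger inhibition and higher numbers for weaker inhibition), compound 3 gives 6640 nM. Going by the values given here, of the two numbers known, compound 3 has the lower one; compound 1 gives 21200 nM, a gap that lies beyond the scatter. For compound 2 only the description "not active" (no number reported) is known, with no number attached, so it cannot be placed on the scale.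

Compound 4 `CN1CCN(CC(=O)N2N=C(c3cc4ccccc4oc3=O)CC2c2ccccc2)CC1` is not yet measured. It differs from compound 3 in one place: (4-methylpiperazin-1-yl)methyl in place of 2-chlorophenyl on a carbonyl carbon. Among the compounds with values here, no measured pair in this set shows a change of this kind, so there is no step to lean on. The two remaining compounds, compound 1 and compound 2, share neither the core of compound 3 nor its amide substituent, and they do not bear on this change.

Without a comparable step, the expectation for compound 4 is a modest loss, near the edge of the scatter and not far beyond it, estimated as a 1.8-fold higher number from compound 3 to compound 4 (0.26 log units; within the scatter). Compound 4 is therefore estimated at 12000 nM, with a range from 3500 nM to 40000 nM.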

Compound 4, half-maximal inhibitory concentration: 46100 nM
Compound 4: middle estimate off by 3.8-fold (0.58 log units), on the low side; the measured number lies above the stated range.
By their numbers in this assay, from the lowest: compound 3; then compound 1; then compound 4.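

In this assay the exchange of 2-chlorophenyl for (4-methylpiperazin-1-yl)methyl on the carbonyl carbon gives a 6.9-fold higher number from compound 3 to compound 4 (0.84 log units; beyond the scatter) and provides the first read of this position in the series, showing that the substituent here is not interchangeable on the shared core. The change replaces a six-membered aromatic carbon ring with a non-aromatic ring carrying hetero atoms and adds hydrogen-bond acceptors, while the printed count shows no net charge on either group. No measured evidence accounts for the loss, so this pair records its size and direction but not its origin.

Several features change together in this single step, so the compounds shown do not separate the loss of the 2-chlorophenyl ring from the entry of the piperazine ring or its methylene link. An unsubstituted phenyl, a benzyl, or a morpholin-4-ylmethyl group on the same carbonyl carbon would help to divide these contributions, and a longer chain between the carbonyl and the 4-methylpiperazine would test the link itself.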